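Swapping Methoxy for Amino on an Inactive Scaffold

The source may report more compounds than this note shows. Statements on the series, on what has been measured and on what is new or still open speak of the compounds shown alone.

Four compounds from a single series were examined in a functional assay on ECa-109 cells (Homo sapiens) for cytotoxicity, read by MTT assay, with a stated time of 48 h; a higher number here means a weaker inhibitor, a lower number a stronger inhibitor. Compound 1 `COc1ccc(-c2c[nH]c(=O)n2-c2cc(OC)c(OC)c(OC)c2)cc1OC` sits at a limit of this assay rather than at a number: in this assay compound 1 gives > 50000 nM. Compound 2 `COc1ccc(-c2c[nH]c(=O)n2-c2cc(OC)c(OC)c(OC)c2)cc1N` differs from it by amino in place of methoxy on an aromatic carbon. In this assay compound 2 likewise reaches only a limit, > 50000 nM. The step that the two limits leave unreadable from compound 1 to compound 2 therefore cannot be read, since both of its ends are limits. Compound 3 `COc1ccc(-c2cn(C(=O)Nc3cc(OC)c(OC)c(OC)c3)c(=O)n2-c2cc(OC)c(OC)c(OC)c2)cc1OC` has a larger core; how its core differs from the core of compound 1 is not broken down here. In this assay compound 3 again stops at a limit, > 50000 nM. The whole record so far is summed up by the limit of > 50000 nM in this assay, at which 3 of the 3 values shown sit.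

Compound 4 `COc1ccc(-c2cn(C(=O)Nc3cc(OC)c(OC)c(OC)c3)c(=O)n2-c2cc(OC)c(OC)c(OC)c2)cc1N` has not yet been measured. Going by the values given here, it differs from compound 3 by amino in place of methoxy on an aromatic carbon, which is the same change as the one from compound 1 to compound 2, made at the same place on the ring. For compound 4 the expected step is a number no higher from compound 3 to compound 4 (the limit leaves the size open), because the limit of > 50000 nM in this assay, at which 3 of the 3 values shown sit, gives no sign that this change, or the change of core, moves any compound away from the limit. In this assay compound 4 is expected at 50000 nM, most likely reported again as a limit, within a range from 20000 nM to 100000 nM.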

Compound 4, half-maximal inhibitory concentration: > 50000 nM
Compound 4 gave a limit, no number; the forecaster's own chance of this, stated with the estimate: 80%; the middle value sits exactly at the limit.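

In this assay compound 4 gives > 50000 nM as a limit of the assay, not a number. Going by these compounds alone, compound 3 also stands at a limit, so the step between these two compounds cannot be read, and no new step comes from this pair. The compounds shown leave open whether amino in place of methoxy, or the change of core, alters cytotoxicity at all, with every result at one ceiling: the limit of > 50000 nM in this assay, at which 4 of the 4 values shown sit.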